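The source may report more compounds than this note shows. Statements on the series, on what has been measured and on what is new or still open speak of the compounds shown alone.

Measured so far:
- compound 1, `CCOC(=O)C1=C(C)NC(C)=C(C(=O)OCC)C1c1c(-c2ccccc2F)nc2sccn12`: 980 nM
- compound 2, `CCOC(=O)C1=C(C)NC(C)=C(C(=O)OCC)C1c1c(-c2ccc(Cl)cc2)nc2sc(Cl)cn12`: 1730 nM
- compound 3, `CCOC(=O)C1=C(C)NC(C)=C(C(=O)OCC)C1c1c(-c2ccc(Cl)c([N+](=O)[O-])c2)nc2sc(C)cn12`: 8480 nM

In an ADME assay on Right cardiac atrium (Cavia porcellus) (on this read-out higher numbers stand for an effect only at larger amounts of compound and lower numbers for an effect already at smaller amounts), compound 1 holds the lowest of the three numbers. Compound 1 and compound 2 lie within the usual scatter of each other, so nothing separates them on this read-out. For the measured compounds named here, compound 3 stands apart: its number lies beyond the scatter above that of compound 1, and it is the only compound of the three whose aryl group carries a nitro group.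

Compound 4, `CCOC(=O)C1=C(C)NC(C)=C(C(=O)OCC)C1c1c(-c2ccc(Br)c([N+](=O)[O-])c2)nc2sccn12`, differs from compound 1 in one place: 4-bromo-3-nitrophenyl in place of 2-fluorophenyl on an aromatic carbon. Going by the values given here, no measured pair isolates this change, so the expectation can rest only on the values shown. The nitro-bearing aryl of compound 3 goes with the highest number in the set, and compound 4 carries an aryl of the same kind, though the rest of its core matches compound 1 rather than compound 3.

The step from compound 1 to compound 4 is therefore expected to run toward higher numbers, beyond the scatter, as a 4.1-fold higher number from compound 1 to compound 4 (0.61 log units; beyond the scatter). For compound 4 the estimate in this assay is 4000 nM, with a range from 1500 nM to 12000 nM.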

Compound 4, half-maximal effective concentration: 4.3 nM
Compound 4: the middle estimate sits 930-fold (2.97 log units) above what was measured; measured number outside the range, below it.
By their numbers in this assay, from the lowest: compound 4; then compounds 1 and 2 (each within the scatter of the next); then compound 3.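

In this assay the aryl group on the aromatic carbon next to the ring nitrogen proves to be a highly sensitive place: 4-bromo-3-nitrophenyl in place of 2-fluorophenyl gives a 230-fold lower number from compound 1 to compound 4 (2.36 log units; beyond the scatter) with the rest of the core of compound 1 unchanged. For the compounds shown here, this is the first step that isolates this position, and it shows that the larger group, with 10 heavy atoms against 7, is compatible with a very low number on this read-out. The change removes the fluorine and adds both the bromine and the nitro group in one move, and nothing at hand gives a measured reason for the size of the step.

Still open, going by these compounds, is how the step divides between the two new substituents, which a phenyl carrying only the bromine or only the nitro group would help to resolve. Also open, on these data alone, is whether the low number survives when the nitro group gives way to an amine or a carboxylic acid, and whether the same aryl group keeps its effect on the substituted cores of the series.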